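A few compounds are considered here, and "the series" means these few. Any claim that something is new, unique, unknown or untested is made for them only; others in the source may bear on it.

Measured in a functional assay on cells (Platelet, Homo sapiens) for inhibition; a lower number here means a stronger inhibitor, a higher number a weaker inhibitor:
- compound 1 `CCOC(=O)c1ccc(-c2nn(Cc3ccc(F)cc3)c3ccccc23)cc1`: > 10000 nM (a limit)
- compound 2 `CCOC(=O)c1ccc(-c2nn(Cc3cccnc3)c3ccccc23)cc1`: > 10000 nM (a limit)
- compound 3 `CCOC(=O)c1ccc(-c2nn(Cc3ccncc3)c3ccccc23)cc1`: > 10000 nM (a limit)

Compound 3 gives no true number, only the limit > 10000 nM. It shares this position with the other two compounds: the limit of > 10000 nM in this assay, at which 3 of the 3 values shown sit.

The next compound, compound 4 `CCCCn1nc(-c2ccc(C(=O)OCC)cc2)c2ccccc21`, has propyl in place of pyridin-4-yl on a saturated chain carbon bound to an aromatic nitrogen. Cut one bond further out, the same difference reads (pyridin-4-yl)methyl to butyl.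

Going by the values given here, three measured steps bear on this change, as all of them swap the group at that same chain carbon: a step that the two limits leave unreadable from compound 1 to compound 2, a step that the two limits leave unreadable from compound 1 to compound 3 and a step that the two limits leave unreadable from compound 2 to compound 3. None has a readable size, so they offer no measured trend to carry over. None of the three groups tried there gave a number, and compound 4 is therefore expected to stay weak, most likely reported at the same limit, with no direction of change that can be supported.

The expected step is a step that the limit leaves unreadable from compound 3 to compound 4.

For compound 4 the estimated value is 15000 nM.

The expected range for compound 4 runs from 5000 nM to 50000 nM.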

Compound 4, half-maximal inhibitory concentration: > 10000 nM
Compound 4: a limit, no number (the forecaster's own chance of this, stated with the estimate: 85%); the middle value is on the limit's open side.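

Compound 4 gives only a limit, as do compound 1, compound 2 and compound 3, so no step among these compounds can be read: the limit of > 10000 nM in this assay, at which 4 of the 4 values shown sit.

The compounds shown leave open how strongly each one inhibits, and whether changing the group on this chain carbon alters inhibition at all.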